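This account rests on a few compounds, and the source may have more. Where it says the series, first, only, none or still open, it means among the compounds named here.

Working notes on the series.

Among the measured compounds shown here, compound 1 `Cn1nc2c(=O)n(CC3(O)CCN(Cc4ccc(-c5ccco5)cc4Cl)CC3)cnc2c1-c1ccc(C2(N)CC2)cc1` gives 66.1 nM in an assay on isolated protein for inhibition of ubiquitin carboxyl-terminal hydrolase 7 (Homo sapiens), with stated times of 30 min and 2 h (a lower number here means a stronger inhibitor, a higher number a weaker inhibitor), and stands at the lowest of the three numbers measured so far. For the measured compounds named here, compound 2 `Cn1nc2c(=O)n(CC3(O)CCN(Cc4ccc(-c5cnco5)cc4Cl)CC3)cnc2c1-c1ccc(CN)cc1` gives 71.6 nM in this assay, and that value and the value of compound 1 lie within the scatter of each other; compound 2 differs from compound 1 in two places, so no single step connects them. Compound 3 `Cn1nc2c(=O)n(CC3(O)CCN(Cc4ccc(-n5ccnc5)cc4Cl)CC3)cnc2c1-c1ccc(CN)cc1` gives 228 nM in this assay. Going by the values given here, the one single-point step on record is a 3.2-fold higher number from compound 2 to compound 3 (0.50 log units; beyond the scatter), a change on the other side of the molecule.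

Compound 4 `Cn1nc2c(=O)n(CC3(O)CCN(Cc4ccc(-c5ccco5)cc4Cl)CC3)cnc2c1-c1ccc(C(N)=O)cc1` is not yet measured. It differs from compound 1 in one place: carbamoyl in place of 1-aminocyclopropyl on an aromatic carbon. Among the compounds with values here, no measured step touches this position: the only step on record concerns the five-membered ring on the chlorinated benzyl group, and the pair of compound 1 and compound 2 changes two places at once. The expectation for compound 4 therefore rests on the structural change alone and carries a wide range. Compound 4 is estimated to give 150 nM in this assay, between 40 nM and 600 nM. That estimate amounts to an expected step of a 2.3-fold higher number from compound 1 to compound 4 (0.36 log units; beyond the scatter), a modest rise that may or may not clear the scatter.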

Compound 4, half-maximal inhibitory concentration: 80.8 nM
Beside the measured number, compound 4's estimate is 1.9-fold (0.27 log units) above it; the measured number falls inside the stated range.
By their numbers in this assay, from the lowest: compounds 1, 2 and 4 (each within the scatter of the next); then compound 3.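

Among the compounds shown here, this is the first measured step at the position para to a large group, and in this assay it reads a 1.2-fold higher number from compound 1 to compound 4 (0.09 log units; within the scatter) with the remainder of compound 1 held constant. For the compounds shown here, the 4-(1-aminocyclopropyl)phenyl and 4-carbamoylphenyl forms therefore cannot be told apart in this pair, even though the exchange removes the three-membered carbon ring and an amine and brings in a ring-free group with a double bond outside aromatic rings; on this background, neither that ring nor that amine is needed for a number in this range, which the earlier compounds could not show since their only single step concerned the five-membered ring on the chlorinated benzyl group. No measurement in hand offers an explanation for why the two groups read alike.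

From the compounds shown here alone, it remains open whether a carboxylic acid, a nitrile or an N-methyl carbamoyl group at this position would also stay within the scatter of compound 1. Going by these compounds, it is equally open whether the exchange of 1-aminocyclopropyl for carbamoyl would read the same with 1,3-oxazol-5-yl or 1H-imidazol-1-yl on the chlorinated benzyl group.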